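This account rests on a few compounds, and the source may have more. Where it says the series, first, only, none or still open, it means among the compounds named here.

Compound 1 `COc1ccc(CNc2nc(Nc3ccc(N4CCN(C)CC4)cn3)ncc2Cl)cc1`: 14900 nM
Compound 2 `Cc1cccc(Nc2nc(Nc3ccc(N4CCN(C)CC4)cn3)ncc2Cl)c1`: 5270 nM

Among the compounds with values here, in a functional assay on MDA-MB-231 cells (Homo sapiens) for inhibition, read by CCK-8 assay, with a stated time of 48 h (on this read-out higher numbers stand for weaker inhibition of growth and lower numbers for stronger inhibition of growth), compound 2 gives 5270 nM, the lower of the two numbers so far and so the stronger growth inhibition. Compound 3 `CC(C)c1ccc(Nc2nc(Nc3ccc(N4CCN(C)CC4)cn3)ncc2Cl)cc1` keeps the shared core and carries 4-isopropylphenyl in place of 3-methylphenyl on a nitrogen on an aromatic ring. Within the data shown here, only one measured step bears on this change. It is a 2.8-fold lower number from compound 1 to compound 2 (0.45 log units; beyond the scatter), a modest change made at the same nitrogen, where 3-methylphenyl replaced 4-methoxybenzyl. That step shows that the number can move with the group at this place, but it does not test the new group. The incoming and outgoing groups each hold one six-membered aromatic ring of carbon only, so no clear direction can be expected, and a step within the scatter seems most likely. The expected step is a 1.2-fold lower number from compound 2 to compound 3 (0.07 log units; within the scatter). For compound 3 the estimate is 4500 nM, with an expected range from 1700 nM to 12000 nM.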

Compound 3, concentration for 50% growth inhibition: 7020 nM
Compound 3: the middle estimate sits 1.6-fold (0.19 log units) below what was measured; low and high end bracket the measured number.
By their numbers in this assay, from the lowest: compounds 2 and 3 (each within the scatter of the next); then compound 1.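

In this assay the change to 4-isopropylphenyl gives a 1.3-fold higher number from compound 2 to compound 3 (0.12 log units; within the scatter), so at this nitrogen the two carbon-only aromatic groups cannot be told apart, even though the incoming group has more heavy atoms. Measured against the 4-methoxybenzyl group, the same new group gives a 2.1-fold lower number from compound 1 to compound 3 (0.33 log units; beyond the scatter), which means that a second group attached directly through its aromatic ring now sits on the lower side of compound 1. No supporting measurement offers an explanation for these numbers.

Compound 1 differs from the other two both in its carbon link to the ring and in its methoxy group, so a plain 4-methoxyphenyl would be needed to separate those two features. A phenyl ring carrying an amine or a carboxylic acid would show whether a group other than carbon or methoxy moves the number further.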